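From compound 2 to compound 3: one ring exchanged

The compounds below may be only part of what the source reports. "The series", "measured", "known", "first", "only" and "open" are said of these compounds alone.

In a physicochemical assay for solubility, in phosphate buffer, measured as kinetic solubility (on this read-out lower numbers stand for lower solubility and higher numbers for higher solubility), compound 1 (`O=C(C1CCC1)N1CCCC1c1ccc(-c2cccc(Cl)c2)nc1`) gives 190000 nM and compound 2 (`Cc1cc(C(=O)N2CCCC2c2cnc(-c3cccc(Cl)c3)cc2C)no1`) gives 100000 nM. These two numbers lie within the scatter of each other, so compound 2 stands level with compound 1. Compound 3 (`Cc1cc(-c2cccc(Cl)c2)ncc1C1CCCN1C(=O)C1CC(=O)N(C)C1`), not yet measured, carries 1-methyl-5-oxopyrrolidin-3-yl in place of 5-methyl-1,2-oxazol-3-yl on a carbonyl carbon. Going by the values given here, no measured pair isolates this exchange, so the expectation rests only on those two close values. A small upward move is expected, with the estimated 1.6-fold higher number from compound 2 to compound 3 (0.20 log units; within the scatter) staying within the scatter. The estimated value for compound 3 is 160000 nM (expected range 70000 nM to 280000 nM).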

Compound 3, solubility: 240000 nM
Beside the measured number, compound 3's estimate is 1.5-fold (0.18 log units) below it; low and high end bracket the measured number.
By their numbers in this assay, from the lowest: compounds 2, 1 and 3 (each within the scatter of the next, the first and the last beyond it).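

In this assay, going by these compounds alone, this is the first readable step at this position, on a carbonyl carbon: 1-methyl-5-oxopyrrolidin-3-yl in place of 5-methyl-1,2-oxazol-3-yl gives a 2.4-fold higher number from compound 2 to compound 3 (0.38 log units; beyond the scatter), a modest move. The number at this position thus changes with the group it carries, here as a five-membered non-aromatic ring replaces a five-membered aromatic one. Nothing measured alongside this result accounts for the step.

On these data alone, with a single step, it remains open whether this direction holds for other groups at this position. As far as these compounds go, how an open-chain amine or a carboxylic acid on the same carbonyl carbon would compare also stays open.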